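Amide carbonyl substituent: hydroxymethyl to tert-butyl

The source may hold more compounds than are shown below. What is called first, only, known or untested is meant among the compounds shown, and "the series" means these compounds.

Going by the values given here, in a functional assay on MKN-45 cells (Homo sapiens) for antiproliferative activity, read by MTT assay, with a stated time of 72 h, tested at 10 uM (a higher number here means more inhibition at the concentration tested (going by the name of the read-out), a lower number less inhibition), compound 2 `O=C(CO)Nc1cc(Oc2ccc(Nc3nccc4[nH]cc(-c5ccc(F)cc5)c(=O)c34)cc2F)ccn1` stands lowest of the two numbers measured, giving 63%; the only neighbour, compound 1 `CC(C)C(=O)Nc1cc(Oc2ccc(Nc3nccc4[nH]cc(-c5ccc(F)cc5)c(=O)c34)cc2F)ccn1`, gives 95.4%. Among the compounds with values here, the single measured step that bears on the next change is a number 32.4 percentage points lower from compound 1 to compound 2 (beyond the scatter), a large loss on moving to the smaller, hydroxyl-bearing group. Compound 3 `CC(C)(C)C(=O)Nc1cc(Oc2ccc(Nc3nccc4[nH]cc(-c5ccc(F)cc5)c(=O)c34)cc2F)ccn1` differs from compound 2 by tert-butyl in place of hydroxymethyl on a carbonyl carbon. That change runs opposite to the measured loss and brings in a group of the same kind as in compound 1, so a large gain is expected, of about a number 27 percentage points higher from compound 2 to compound 3 (beyond the scatter). Compound 3 is therefore expected near 90%, within 72% to 100%.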

Compound 3, a percentage reported as inhibition, at one concentration (the size of the read-out at that concentration, not a potency): 62.5%
The estimate for compound 3 lay 27.5 percentage points above the measured number, and the stated range ends above it.
By their numbers in this assay, from the lowest: compounds 3 and 2 (each within the scatter of the next); then compound 1.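

In this assay the step is a number 0.5 percentage points lower from compound 2 to compound 3 (within the scatter), so hydroxymethyl and tert-butyl on this carbonyl carbon are not told apart despite their different sizes. One added methyl gives a number 32.9 percentage points lower from compound 1 to compound 3 (beyond the scatter), so the high number of compound 1 does not carry over to tert-butyl, and the number here does not follow group size across the three compounds. Nothing available explains this result.

As far as these compounds go, whether a cyclopropyl ring, an ethyl group or a dimethylamino group on this carbonyl carbon would keep the number of compound 1 remains open. Potency also remains open, as these are readings at one concentration.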